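Chloro on the benzoyl ring in two indole cores

A few compounds are considered here, and "the series" means these few. Any claim that something is new, unique, unknown or untested is made for them only; others in the source may bear on it.

Measured so far:
compound 1 `O=C(CN1CCN(C(=O)c2ccccc2)CC1)N1CCN(CCCc2c[nH]c3ccccc23)CC1` gives > 200000 nM
compound 2 `O=C(CN1CCN(C(=O)c2cccc(Cl)c2)CC1)N1CCN(CCCc2c[nH]c3ccccc23)CC1` gives 99100 nM
compound 3 `COc1ccc2[nH]cc(CCCN3CCN(C(=O)CN4CCN(C(=O)c5ccccc5)CC4)CC3)c2c1` gives > 200000 nM

In an ADME assay on HEK293 cells (Homo sapiens) for cytotoxicity, read by MTT assay, with a stated time of 72 h (on this read-out lower numbers stand for stronger inhibition and higher numbers for weaker inhibition), compound 1 reaches only a limit of the assay, > 200000 nM. Compound 2 carries chloro in place of hydrogen on an aromatic carbon and gives 99100 nM; the result is an at least 2.0-fold lower number from compound 1 to compound 2 (0.30 log units; that floor lies within the scatter). Compound 3 differs from compound 1 by methoxy in place of hydrogen on an aromatic carbon, and in this assay compound 3 again returns a limit, > 200000 nM, so a step that the two limits leave unreadable from compound 1 to compound 3; both limits sit at the limit of > 200000 nM in this assay, at which 2 of the 3 values shown sit. Compound 4 `COc1ccc2[nH]cc(CCCN3CCN(C(=O)CN4CCN(C(=O)c5ccc(Cl)cc5)CC4)CC3)c2c1` is not yet measured; it carries chloro in place of hydrogen on an aromatic carbon, the same kind of change as in compound 2, though here para to a large group rather than meta to a large group. Compound 4 is expected to give 130000 nM, between 55000 nM and 250000 nM, because the earlier step of an at least 2.0-fold lower number from compound 1 to compound 2 (0.30 log units; that floor lies within the scatter) was small. That means an expected at least 1.5-fold lower number from compound 3 to compound 4 (0.18 log units; that floor lies within the scatter).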

Compound 4, half-maximal inhibitory concentration: 117000 nM
Compound 4: middle estimate off by 1.1-fold (0.05 log units), on the high side, and the stated range covers the measured number.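

In this assay, chloro in place of hydrogen on the benzoyl ring gives an at least 1.7-fold lower number from compound 3 to compound 4 (0.23 log units; that floor lies within the scatter), so the step is again small and in the same direction as on the core of compound 1. Each step is only a floor, since the starting value of each pair is a limit of the assay: the limit of > 200000 nM in this assay, at which 2 of the 4 values shown sit. The change thus points the same way on both cores, but this does not show that it has the same size: the same change on two cores in this assay, an at least 2.0-fold lower number (0.30 log units; that floor lies within the scatter) from compound 1 to compound 2 and an at least 1.7-fold lower number (0.23 log units; that floor lies within the scatter) from compound 3 to compound 4; the limit leaves it open whether they differ.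

The compounds shown leave open whether the place of the chloro on the ring matters on a single core. They also leave open how a fluoro or trifluoromethyl group on that ring, or a longer chain, would read in this assay.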